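A few compounds are considered here, and "the series" means these few. Any claim that something is new, unique, unknown or untested is made for them only; others in the source may bear on it.

Compound 2 `COc1cc(-c2nn(-c3cccc(NC(=O)c4cccc(C(F)(F)F)c4)c3)cc2-c2ccncc2)ccc1Cl` is one of four close relatives examined in a functional assay on SF-295 cells (Homo sapiens) for inhibition, read by sulforhodamine B assay, with a stated time of 48 h; a higher number here means that more compound is tolerated, a lower number that less compound is tolerated. In this assay compound 2 gives only a limit, > 50000 nM, and this is where it stands (the limit of > 50000 nM in this assay, at which 1 of the 3 values shown sits). Compound 1 `COc1cc(-c2nn(-c3cccc(NC(=O)c4ccc(Cl)c(C(F)(F)F)c4)c3)cc2-c2ccncc2)ccc1Cl` likewise gives only a limit in this assay, > 32500 nM (the limit of > 32500 nM in this assay, at which 1 of the 3 values shown sits). For the measured compounds named here, the one measured step, from compound 1 to compound 2, is therefore unreadable: a step that the two limits leave unreadable from compound 1 to compound 2. Going by the values given here, compound 3 `O=C(Nc1cccc(-n2cc(-c3ccncc3)c(-c3ccc(Cl)c(O)c3)n2)c1)Nc1cc(C(F)(F)F)cc(C(F)(F)F)c1` is the sole relative with a number in this assay, where compound 3 gives 4390 nM. Compound 4 `COc1cc(-c2nn(-c3cccc(NC(=O)Nc4cccc(C(F)(F)F)c4)c3)cc2-c2ccncc2)ccc1Cl` has not yet been measured in this assay; it differs from compound 2 by (3-(trifluoromethyl)phenyl)amino in place of 3-(trifluoromethyl)phenyl on a carbonyl carbon. Among the compounds with values here, no measured step follows this change alone, and compound 3 differs from compound 4 in more than one place, so its value cannot be read as a step. Within the data shown here, the expected step of an at least 2.5-fold lower number from compound 2 to compound 4 (0.39 log units; beyond the scatter) therefore rests on little beyond the single number that compound 3 shows. Compound 4 is estimated at 20000 nM, with a range from 5000 nM to 60000 nM.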

Compound 4, concentration lethal to 50% of the cells: 3200 nM
Compound 4: the middle estimate sits 6.3-fold (0.80 log units) above what was measured, and the stated range ends above it.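

For the compounds shown here, with (3-(trifluoromethyl)phenyl)amino in place of 3-(trifluoromethyl)phenyl on a carbonyl carbon, this assay gives an at least 15-fold lower number from compound 2 to compound 4 (1.19 log units; beyond the scatter), the first readable step at this position. The same place gives an at least 10-fold lower number from compound 1 to compound 4 (1.00 log units; beyond the scatter) when the group that leaves is 4-chloro-3-(trifluoromethyl)phenyl, and both steps give only a lower bound on the size of the change. Compound 2 stands only at a limit: the limit of > 50000 nM in this assay, at which 1 of the 4 values shown sits.

An oxygen or a methylene in that place, or a methyl on the new nitrogen, would tell whether the step follows the hydrogen on that nitrogen or only the longer link. On these data alone, it also stays open whether the chloro of 4-chloro-3-(trifluoromethyl)phenyl changes the number once this nitrogen is present, as the step from compound 1 to compound 2 cannot be read.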